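Swapping a fluoro for a phenyl on a cytotoxic amide

This account rests on a few compounds, and the source may have more. Where it says the series, first, only, none or still open, it means among the compounds named here.

Of the compounds shown here, two have been tested in a functional assay on CAL-27 cells (Homo sapiens) for cytotoxicity, read by MTT assay, with a stated time of 72 h; on this read-out higher numbers stand for weaker inhibition and lower numbers for stronger inhibition. Compound 1, `Cc1cc(C)cc(CNC(=O)CN(CCCCCC(=O)Nc2ccccc2N)C(=O)c2cc(C)cc(C)c2)c1`, gives 19300 nM in this assay. Compound 2, `Cc1cc(C)cc(C(=O)N(CC(=O)NCc2ccccc2)Cc2ccc(C(=O)Nc3cc(F)ccc3N)cc2)c1`, gives 5720 nM and so holds the lower of the two numbers, a gap to compound 1 that lies beyond the usual scatter. Compound 3, `Cc1cc(C)cc(C(=O)N(CC(=O)NCc2ccccc2)Cc2ccc(C(=O)Nc3cc(-c4ccccc4)ccc3N)cc2)c1`, has not been measured. It differs from compound 2 in one place: phenyl in place of fluoro on an aromatic carbon. Among the compounds with values here, no measured pair in this set shows what such a change does, so the expectation must rest on compound 2 alone and on the size of the change. A phenyl entering in place of fluoro is a sizeable addition, and the step from compound 2 is expected to be a moderate fall in the number, a 2.3-fold lower number from compound 2 to compound 3 (0.36 log units; beyond the scatter), meaning somewhat stronger inhibition. For compound 3 the estimate in this assay is 2500 nM, with a plausible range from 800 nM to 8000 nM.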

Compound 3, half-maximal inhibitory concentration: 8900 nM
For compound 3 the middle estimate is 3.6-fold (0.55 log units) below the measured one; measured number above the stated range.
By their numbers in this assay, from the lowest: compounds 2 and 3 (each within the scatter of the next); then compound 1.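

In this assay, the aromatic carbon para to an amino group takes phenyl in place of fluoro, and the result is a 1.6-fold higher number from compound 2 to compound 3 (0.19 log units; within the scatter). A single fluorine atom gives way here to six carbon atoms and a whole aromatic ring, yet the read-out cannot tell compound 2 and compound 3 apart, so this one swap gives no clear gain or loss of cytotoxicity on these cells. Nothing available bears on the reason for this result.

Going by these compounds, what an amine, a methoxy group or a carboxylic acid would do on this same carbon remains open. Also open, on these data alone, is whether a phenyl carrying a group of its own, such as a hydroxyl, would stay within the scatter of compound 3 or move clearly away from it.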